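Ethoxy to cyclopropyl on a low-clearance series

A few compounds are considered here, and "the series" means these few. Any claim that something is new, unique, unknown or untested is made for them only; others in the source may bear on it.

Measured in an in vitro ADME assay on microsomes from liver (Homo sapiens) for metabolic stability; a higher number here means faster removal of the compound, a lower number slower removal:
Compound 1 `Cc1cc(Nc2ccc(S(F)(F)(F)(F)F)cc2)n2nc(C3CC3)nc2n1`: < 5 mL.min-1.g-1, a limit of the assay
Compound 2 `CCOc1nc2nc(C)cc(Nc3ccc(C(F)(F)F)cc3)n2n1`: 7 mL.min-1.g-1

Going by the values given here, compound 2 gives 7 mL.min-1.g-1, the only actual number so far. Compound 3 `Cc1cc(Nc2ccc(C(F)(F)F)cc2)n2nc(C3CC3)nc2n1` differs from compound 2 in one place: cyclopropyl in place of ethoxy on an aromatic carbon. Cyclopropyl stands in place of ethoxy on an aromatic carbon, between two ring nitrogen atoms. Among the compounds with values here, no measured pair isolates this change, so its effect in this assay has no direct precedent. Within the data shown here, the only guide is compound 1, which also carries cyclopropyl and reports < 5 mL.min-1.g-1, a limit of the assay. A slight drop is therefore expected at most, and the estimated step, a 1.2-fold lower number from compound 2 to compound 3 (0.07 log units; within the scatter), stays within the scatter. For compound 3 the expected value is 6 mL.min-1.g-1, with an estimated range of 3 mL.min-1.g-1 to 12 mL.min-1.g-1.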

Compound 3, intrinsic clearance in microsomes: < 5 mL.min-1.g-1
Compound 3 ended at the assay's limit; the forecaster's own chance of this, stated with the estimate: 45%; at least 1.2-fold (0.07 log units) between middle value and limit.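

In this assay, going by these compounds alone, the change from ethoxy to cyclopropyl on the shared core now has a direct reading, which the earlier compounds did not give: an at least 1.4-fold lower number from compound 2 to compound 3 (0.14 log units; that floor lies within the scatter). Compound 3 gives < 5 mL.min-1.g-1, which is a limit of the assay and not a number, so the true step may be larger, but its printed floor alone does not separate the two compounds. The step between compound 1 and compound 3 cannot be read, because both compounds sit at the same limit: the limit of < 5 mL.min-1.g-1 in this assay, at which 2 of the 3 values shown sit.

From the compounds shown here alone, the true value of compound 3 remains open, as does the size of the step between ethoxy and cyclopropyl. Also open, going by these compounds, is how an amine or a longer alkyl chain would read at this place, on an aromatic carbon between two ring nitrogen atoms.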